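The source may hold more compounds than are shown below. What is called first, only, known or untested is meant among the compounds shown, and "the series" means these compounds.

Measured compounds:
compound 1 `N#CC1(c2cc(CCO)cc(-c3ccnc4[nH]nc(C(F)(F)F)c34)c2)CC1` — 25 nM in an assay on isolated protein for inhibition of protein kinase C epsilon type (Homo sapiens), read by coupled enzyme assay; a lower number here means a stronger inhibitor, a higher number a weaker inhibitor
compound 2 `CCC(O)Cc1cc(-c2ccnc3[nH]nc(C(F)(F)F)c23)cc(C2(C#N)CC2)c1` — 49 nM in this assay

Compound 2 holds the higher of the two numbers measured in this assay; its nearest neighbour is compound 1, and the gap is a 2.0-fold higher number from compound 1 to compound 2 (0.29 log units; within the scatter), so the two values are not told apart.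

Compound 3 `N#CC1(c2cc(CC(O)C3CC3)cc(-c3ccnc4[nH]nc(C(F)(F)F)c34)c2)CC1` is the next member. Its change from compound 2 is cyclopropyl in place of ethyl on a saturated chain carbon bound to an oxygen on a saturated carbon and a saturated chain carbon. Going by the values given here, the single measured step that touches this position is the growth of hydrogen to ethyl at the same carbon, a 2.0-fold higher number from compound 1 to compound 2 (0.29 log units; within the scatter), which stayed within the scatter. Replacing that ethyl by cyclopropyl is a further change at this carbon of comparable extent. Nothing measured here points to a shift beyond the scatter in either direction.

The expected step is therefore a 1.0-fold higher number from compound 2 to compound 3 (0.01 log units; within the scatter), a move not exceeding the usual scatter. For compound 3 the estimate in this assay is 50 nM, with a range from 20 nM to 125 nM.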

Compound 3, inhibition constant: 30 nM
Beside the measured number, compound 3's estimate is 1.7-fold (0.22 log units) above it; the measured number falls inside the stated range.
By their numbers in this assay, from the lowest: compounds 1, 3 and 2 (each within the scatter of the next).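

At the saturated chain carbon bound to the oxygen, a three-membered non-aromatic ring now stands in place of an open chain, and in this assay this change stays small (cyclopropyl for ethyl: a 1.6-fold lower number from compound 2 to compound 3 (0.21 log units; within the scatter)). Measured against the unsubstituted chain, the ring also makes little difference (cyclopropyl for hydrogen: a 1.2-fold higher number from compound 1 to compound 3 (0.08 log units; within the scatter)), so hydrogen, ethyl and cyclopropyl at this carbon are not told apart. No data that could explain these small steps are at hand.

From the compounds shown here alone, whether this flat picture holds for a substituent carrying other atoms at this carbon, such as an amine or a carboxylic acid, or for a longer chain remains open. Also open is what happens without the oxygen, since every compound shown carries it.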